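The source may hold more compounds than are shown below. What is called first, only, known or untested is meant among the compounds shown, and "the series" means these compounds.

Compound 1, `Cc1cc(NC(=O)c2cc([N+](=O)[O-])ccc2Cl)cc(-c2nc3ccccc3s2)c1O`: 430 nM
Compound 2, `Cc1ccc(-c2nc3ccccc3s2)cc1NC(=O)c1cc([N+](=O)[O-])c(N2CCC(C(=O)O)CC2)cc1Cl`: 590 nM
Compound 3, `O=C(Nc1nc2ccc(Cl)cc2s1)c1cc([N+](=O)[O-])ccc1Cl`: 1200 nM

In a physicochemical assay for solubility, read by spectrophotometry, in phosphate buffer, measured as kinetic solubility, with a stated time of 18 h, at pH 7.4 (a lower number here means a less soluble compound, a higher number a more soluble compound), compound 2 gives 590 nM, which stands second highest of the three numbers. The nearest number belongs to compound 1 with 430 nM, a gap that lies within the scatter, so the two cannot be set in order. The furthest belongs to compound 3 with 1200 nM, a gap that lies beyond the scatter. For the measured compounds named here, no pair among the measured compounds differs in a single place, so none of these gaps can be tied to one structural change.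

Compound 4, `Cc1ccc(-c2nc3ccccc3s2)cc1NC(=O)c1cc([N+](=O)[O-])c(N(C)C)cc1Cl`, has not yet been measured. It differs from compound 2 in one place: dimethylamino in place of 4-carboxypiperidin-1-yl on an aromatic carbon. Going by the values given here, none of the measured compounds shows this change, so there is no measured step on which to rest an expectation. The account therefore treats the step of a 2.0-fold lower number from compound 2 to compound 4 (0.29 log units; within the scatter) as an expected modest move downward, with room on either side, since compound 2 gives 590 nM as its starting point and nothing else constrains the outcome. Compound 4 is estimated at 300 nM, with the expected range running from 100 nM to 900 nM.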

Compound 4, solubility: 30 nM
The estimate for compound 4 lay 10-fold (1.00 log units) above the measured number; measured number below the stated range.
By their numbers in this assay, from the lowest: compound 4; then compounds 1 and 2 (each within the scatter of the next); then compound 3.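

In this assay, for the compounds shown here, the exchange of 4-carboxypiperidin-1-yl for dimethylamino on an aromatic carbon, ortho to a nitro group and meta to a chloro group, gives a 20-fold lower number from compound 2 to compound 4 (1.29 log units; beyond the scatter), the first comparison here that isolates a single place, and the step is large. It shows that the group at this position can move the number a long way on this core. Going by these compounds alone, none of the earlier compounds differed in only one place. The exchange alters several counted features at once, since the leaving group has a six-membered non-aromatic ring, 9 heavy atoms and 1 hydrogen-bond donor while the entering group has no ring, 3 heavy atoms and 0 hydrogen-bond donors, and no measurement shown bears on what lies behind the drop.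

The compounds shown leave open whether the step follows the carboxylic acid, the piperidine ring or both, which a plain piperidin-1-yl or a short chain ending in a carboxylic acid at this position would help to separate. They also leave open where a morpholine or a primary amine at the same place would fall.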